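The compounds below may be only part of what the source reports. "The series", "measured", "known", "first", "only" and "open" are said of these compounds alone.

In a functional assay on L02 cells (Homo sapiens) for inhibition, read by MTT assay, with a stated time of 72 h (on this read-out lower numbers stand for stronger inhibition and higher numbers for weaker inhibition), compound 1, `C=C(c1cc(Cl)cc(Cl)c1OCc1ccccc1)C1COC2(CCCCC2)OO1`, reads > 100000 nM, which is a limit of the assay and not a number. Compound 2, `C=C(c1ccc(F)c(F)c1)C1COC(C)(C)OO1`, reads > 100000 nM, again a limit and not a number. For the measured compounds named here, compound 3, `C=C(c1ccc(OC)c(F)c1)C1COC2(CCCC2)OO1`, gives 18500 nM, the only true number among the three measured compounds.

Compound 4, `C=C(c1ccc(F)c(F)c1)C1COC2(CCCC2)OO1`, has not yet been measured. It differs from compound 3 at one place, with fluoro in place of methoxy on an aromatic carbon, ortho to a fluoro group and para to a large group: fluoro in place of methoxy on an aromatic carbon.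

Going by the values given here, no measured pair isolates this change, so the expectation is only loosely grounded. The aromatic ring of compound 2 bears the same fluoro groups as that of compound 4, and compound 2 stays at the limit of > 100000 nM. A step toward weaker inhibition in this assay is therefore expected, modestly beyond the usual scatter. The estimated change is a 1.9-fold higher number from compound 3 to compound 4 (0.28 log units; within the scatter). For compound 4 the estimated value is 35000 nM, with an expected range of 10000 nM to 100000 nM.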

Compound 4, half-maximal inhibitory concentration: 8840 nM
Estimate against measurement, compound 4: 4.0-fold (0.60 log units) above; measured number outside the range, below it.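

In this assay, fluoro in place of methoxy on this aromatic carbon, ortho to a fluoro group and para to a large group, gives a 2.1-fold lower number from compound 3 to compound 4 (0.32 log units; beyond the scatter) and so keeps measurable inhibition, showing that the methoxy group is not required for it in this pair. Compound 2 reads > 100000 nM, which is a limit of the assay and not a number. It carries the same fluoro groups as compound 4 and differs from it in one place on the shared core, but the step between these two compounds cannot be read: the limit of > 100000 nM in this assay, at which 2 of the 4 values shown sit.

On these data alone, only methoxy and fluoro are compared at this position, so it remains open how a hydroxy group, an amine or a longer chain such as ethoxy would read there. As far as these compounds go, whether the step from methoxy to fluoro would hold on another core also remains open.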